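The compounds below may be only part of what the source reports. "The series", "measured", "known", "first", "only" and "open" are said of these compounds alone.

Compound 1 `COc1cc(OC)cc(OS(=O)(=O)c2ccc(N3CCN(C)C3=O)cc2)c1` and compound 2 `COc1cc(OS(=O)(=O)c2ccc(N3CCN(C)C3=O)cc2)cc(OC)c1OC` share a core, and in a functional assay on HT-29 cells (Homo sapiens) for antiproliferative activity, read by sulforhodamine B assay, with a stated time of 48 h (a lower number here means a stronger inhibitor, a higher number a weaker inhibitor), compound 1 gives 190 nM, while compound 2 gives 62 nM. The change between them is methoxy in place of hydrogen on an aromatic carbon, and it made a 3.1-fold lower number from compound 1 to compound 2 (0.49 log units; beyond the scatter).

Compound 3 `CCN1CCN(c2ccc(S(=O)(=O)Oc3cccc(OC)c3)cc2)C1=O` has a different core; the difference between the two cores is not broken down here. In this assay compound 3 gives 22000 nM, the highest number among the three measured compounds. Compound 4 `CCN1CCN(c2ccc(S(=O)(=O)Oc3ccc(OC)c(OC)c3)cc2)C1=O` is made from compound 3 by methoxy in place of hydrogen on an aromatic carbon. This is the same kind of change as that from compound 1 to compound 2, though the place differs: in compound 1 the entering methoxy sits ortho to two methoxy groups, whereas in compound 3 it sits ortho to a methoxy group.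

Because the earlier step is a 3.1-fold lower number from compound 1 to compound 2 (0.49 log units; beyond the scatter), a step of similar or somewhat larger size is expected here, a 4.4-fold lower number from compound 3 to compound 4 (0.64 log units; beyond the scatter). In this assay compound 4 is expected to give about 5000 nM, estimated to lie between 1500 nM and 15000 nM.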

Compound 4, half-maximal inhibitory concentration: 37000 nM
Compound 4: the middle estimate sits 7.4-fold (0.87 log units) below what was measured, outside the stated range (above it).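

In this assay, the effect of methoxy in place of hydrogen on an aromatic carbon did not carry over from one core to the other: the same change on two cores in this assay, a 3.1-fold lower number (0.49 log units; beyond the scatter) from compound 1 to compound 2 and a 1.7-fold higher number (0.23 log units; within the scatter) from compound 3 to compound 4, 5.2-fold (0.71 log units) apart, beyond the scatter of two such steps. On the core of compound 3, the change gave a 1.7-fold higher number from compound 3 to compound 4 (0.23 log units; within the scatter), so this pair cannot be told apart in this assay, and the added methoxy, ortho to a methoxy group and para to a large group, brought no gain like the one seen on the other core. This does not show that the core alone sets the outcome, since the entering methoxy also sits at a different place in the two steps, and a single pair on each core cannot separate those two differences.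

The compounds shown leave open whether methoxy entering at the same place on both cores would give steps that agree. They also leave open whether an amine or a fluorine atom at that place would shift the number on either core.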